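A few compounds are considered here, and "the series" means these few. Any claim that something is new, unique, unknown or untested is made for them only; others in the source may bear on it.

Of the compounds shown here, three have been measured in a functional assay on HT-29 cells (Homo sapiens) for inhibition, read by MTT assay, with a stated time of 48 h; on this read-out lower numbers stand for stronger inhibition and higher numbers for weaker inhibition. Compound 1 `Cc1ccc(NC(=S)NC(=O)c2ccc(OCc3ccccc3)cc2)cc1-c1nc2ccccc2[nH]1` gives 28800 nM in this assay, compound 2 `Cc1ccc(NC(=S)NC(=O)c2ccc(OCc3ccccc3F)cc2)cc1-c1nc2ccccc2[nH]1` gives 1870 nM, and compound 3 `Cc1ccc(NC(=O)NC(=O)c2ccc(OCc3cccc(Cl)c3)cc2)cc1-c1nc2ccccc2[nH]1` gives 15400 nM. Compound 3 therefore stands second highest of the three numbers: its nearest neighbour is compound 1, which lies within the scatter of it, while compound 2 lies furthest away, beyond the scatter.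

The step in question leads from compound 3 to compound 4 `Cc1ccc(NC(=O)NC(=O)c2ccc(OCc3cccc(F)c3)cc2)cc1-c1nc2ccccc2[nH]1`. The change is fluoro in place of chloro on an aromatic carbon. Going by the values given here, no measured pair covers this exact swap. Among the compounds with values here, the only measured step, a 15-fold lower number from compound 1 to compound 2 (1.19 log units; beyond the scatter), put fluoro onto the same benzyl ring and was large, but it started from hydrogen rather than chloro, and compound 1 and compound 2 carry a core that differs in one place from the core shared by compound 3 and compound 4, so it can guide the expectation only loosely. With no direct comparison of chloro against fluoro among the measured compounds, the expected step of a 1.5-fold lower number from compound 3 to compound 4 (0.19 log units; within the scatter) is small, leaning if anything toward a lower number. Compound 4 is estimated at 10000 nM in this assay, with a likely range from 3000 nM to 40000 nM.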

Compound 4, half-maximal inhibitory concentration: 38200 nM
The estimate for compound 4 lay 3.8-fold (0.58 log units) below the measured number; low and high end bracket the measured number.
By their numbers in this assay, from the lowest: compound 2; then compounds 3, 1 and 4 (each within the scatter of the next, the first and the last beyond it).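

On the shared core of compound 3 and compound 4, fluoro in place of chloro on the aromatic ring, meta to a large group, gives a 2.5-fold higher number from compound 3 to compound 4 (0.39 log units; beyond the scatter) in this assay. Going by these compounds alone, at this position, then, fluoro goes with weaker inhibition than chloro, a direct comparison of the two halogens that the earlier compounds did not offer. The earlier fluoro step, a 15-fold lower number from compound 1 to compound 2 (1.19 log units; beyond the scatter), ran the opposite way, so adding fluoro to this ring does not lower the number in every case, although that step differs from this one in both the group replaced and the core. Nothing measured here explains the direction or size of the new step.

The compounds shown leave open how hydrogen, a methoxy group or a nitrile at this same place on the core of compound 3 would compare with chloro and fluoro. They also leave open whether chloro and fluoro would keep this order on the core of compound 1, which would show whether the order depends on the core.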